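Meta substituent scan on the anilino core

A few compounds are considered here, and "the series" means these few. Any claim that something is new, unique, unknown or untested is made for them only; others in the source may bear on it.

Measured in a functional assay for inhibition, with Homo sapiens as the target; a lower number here means a stronger inhibitor, a higher number a weaker inhibitor:
compound 1 `NS(=O)(=O)c1cccc(Nc2nccc(-c3ccncc3)n2)c1` gives 500 nM
compound 2 `CN(C)c1cccc(Nc2nccc(-c3ccncc3)n2)c1` gives 3700 nM
compound 3 `c1ccc(Nc2nccc(-c3ccncc3)n2)cc1` gives 900 nM

Compound 3 stands second highest of the three numbers; one step is a 1.8-fold higher number from compound 1 to compound 3 (0.26 log units; within the scatter), within the scatter, while compound 2 sits a 4.1-fold lower number from compound 2 to compound 3 (0.61 log units; beyond the scatter) away, beyond it. Compound 4 `CC(=O)Nc1cccc(Nc2nccc(-c3ccncc3)n2)c1` carries acetamido in place of hydrogen on an aromatic carbon. The relevant steps are the two substitutions at the same position: sulfamoyl, one hydrogen-bond donor and acceptor like acetamido, left the number a 1.8-fold higher number from compound 1 to compound 3 (0.26 log units; within the scatter); dimethylamino moved it a 7.4-fold higher number from compound 1 to compound 2 (0.87 log units; beyond the scatter) from compound 1. No change beyond the scatter is therefore expected for compound 4 in this assay, a step of a 1.3-fold lower number from compound 3 to compound 4 (0.11 log units; within the scatter), giving an estimate of 700 nM with a range of 250 nM to 2500 nM.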

Compound 4, half-maximal inhibitory concentration: 2700 nM
Compound 4: the middle estimate sits 3.9-fold (0.59 log units) below what was measured; the whole stated range lies below it.
By their numbers in this assay, from the lowest: compounds 1 and 3 (each within the scatter of the next); then compounds 4 and 2 (each within the scatter of the next).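

At this position in this assay, acetamido does not follow sulfamoyl, with a 5.4-fold higher number from compound 1 to compound 4 (0.73 log units; beyond the scatter), and instead falls in with dimethylamino, at a 1.4-fold lower number from compound 2 to compound 4 (0.14 log units; within the scatter). With a 3.0-fold higher number from compound 3 to compound 4 (0.48 log units; beyond the scatter), a second group now raises the number over plain hydrogen, leaving sulfamoyl in compound 1 as the one substituent shown that stays within the scatter of hydrogen. Nothing available accounts for the gap between sulfamoyl and acetamido.

Open, on these data alone, is whether a carboxylic acid or a primary amine on this aromatic carbon would stay near hydrogen, as sulfamoyl does, or raise the number, as acetamido and dimethylamino do.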